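The compounds below may be only part of what the source reports. "The series", "measured", "known", "first", "only" and "open" are said of these compounds alone.

Compound 1 `C/C(=C/c1ccc(Cc2cccnc2)n1-c1ccccc1)C(=O)O` is the weakest inhibitor of the three compounds tested in a functional assay on microsomes from aorta for inhibition of Thromboxane-A synthase (Homo sapiens), in the presence of a further agent that is not named here; on this read-out higher numbers stand for weaker inhibition and lower numbers for stronger inhibition. Compound 1 gives 24000 nM, whereas compound 2 `Cn1c(/C=C/C(=O)O)ccc1Cn1ccnc1` gives 3800 nM and compound 3 `C/C(=C\c1ccc(Cn2ccnc2)[nH]1)C(=O)O` gives 9100 nM, both differences beyond the usual scatter. Compound 4 `C/C(=C/c1ccc(Cc2cccnc2)n1C)C(=O)O` differs from compound 1 in one place: methyl in place of phenyl on an aromatic nitrogen. No such exchange has been measured between two tested compounds, so the expectation rests on the numbers shown: compound 2 and compound 3, which carry no phenyl on the aromatic nitrogen, sit at lower numbers than compound 1. Compound 4 is therefore expected to land at a lower number, a moderate step of a 4.0-fold lower number from compound 1 to compound 4 (0.60 log units; beyond the scatter). For compound 4 the estimate in this assay is 6000 nM, within a range from 2000 nM to 20000 nM.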

Compound 4, half-maximal inhibitory concentration: 50 nM
Beside the measured number, compound 4's estimate is 120-fold (2.08 log units) above it, outside the stated range (below it).
By their numbers in this assay, from the lowest: compound 4; then compound 2; then compound 3; then compound 1.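

In this assay the exchange of phenyl for methyl on the aromatic nitrogen is a large step (a 480-fold lower number from compound 1 to compound 4 (2.68 log units; beyond the scatter)), showing that this single position can strongly change the inhibition. The earlier compounds shown here offered no pair differing in one place, so they could not isolate this position. Nothing measured here explains the size of the step. Going by these compounds, whether ethyl or a longer chain on this nitrogen would stay close to compound 4 remains open, and so does the effect of benzyl there.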